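The source may hold more compounds than are shown below. What is called first, only, known or untested is meant among the compounds shown, and "the series" means these compounds.

Measured in a physicochemical assay, read by spectrophotometry, with a stated time of 30 min; on this read-out lower numbers stand for stronger inhibition and higher numbers for weaker inhibition:
- compound 1 `O=C(CC(c1ccccc1)c1c[nH]c2ccccc12)c1c(O)c2ccccc2oc1=O`: 12.4 ug/mL
- compound 2 `O=C(CC(c1ccccc1Cl)c1c[nH]c2ccccc12)c1c(O)c2ccccc2oc1=O`: 39.6 ug/mL

Compound 2 stands highest of these two numbers in this assay, so it is the weaker inhibitor of the pair. The next compound, compound 3 `O=C(CC(c1ccc(Cl)cc1)c1c[nH]c2ccccc12)c1c(O)c2ccccc2oc1=O`, differs from compound 2 as follows: 4-chlorophenyl in place of 2-chlorophenyl on a saturated chain carbon bound to an aromatic carbon and a saturated chain carbon. In words, this is 4-chlorophenyl in place of 2-chlorophenyl on a saturated chain carbon bound to an aromatic carbon and a saturated chain carbon.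

Among the compounds with values here, only one measured step bears on this change, and only indirectly: a 3.2-fold higher number from compound 1 to compound 2 (0.50 log units; beyond the scatter), a modest step for chloro in place of hydrogen on an aromatic carbon. Within the data shown here, no measured compound carries the 4-chlorophenyl group. A small move back towards compound 1 is therefore expected, with a lower number but probably no change beyond the scatter. The expected step is a 1.6-fold lower number from compound 2 to compound 3 (0.20 log units; within the scatter). For compound 3 the estimated value is 25 ug/mL, with an expected range of 9 ug/mL to 65 ug/mL.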

Compound 3, half-maximal inhibitory concentration: 46.4 ug/mL
The estimate for compound 3 lay 1.9-fold (0.27 log units) below the measured number; the range from low to high includes it.
By their numbers in this assay, from the lowest: compound 1; then compounds 2 and 3 (each within the scatter of the next).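

In this assay, 4-chlorophenyl in place of 2-chlorophenyl on the saturated chain carbon gives a 1.2-fold higher number from compound 2 to compound 3 (0.07 log units; within the scatter), so the two chloro placements cannot be told apart on this read-out. The step from the unsubstituted phenyl to the 4-chlorophenyl, a 3.7-fold higher number from compound 1 to compound 3 (0.57 log units; beyond the scatter), lies beyond the scatter, as does a 3.2-fold higher number from compound 1 to compound 2 (0.50 log units; beyond the scatter), so across these compounds the higher number appears with either chlorophenyl group. No measurement on the series offers an explanation for this result.

On these data alone, it remains open whether the higher number is particular to chloro or also comes with a methoxy group, an amine or a carboxylic acid on this phenyl ring. Also open, as far as these compounds go, is how this assay responds when a longer chain replaces the phenyl on the saturated chain carbon.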